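The source may hold more compounds than are shown below. What is called first, only, known or untested is meant among the compounds shown, and "the series" means these compounds.

Measured in a functional assay (Mus musculus) for inhibition, with a stated time of 5 days; a lower number here means a stronger inhibitor, a higher number a weaker inhibitor:
- Compound 1 `CCOC(=O)/C=C/c1cn(-c2ccc(O)cc2)nc1-c1cccc(O)c1`: 14000 nM
- Compound 2 `O=C(O)/C=C/c1cn(-c2ccc(O)cc2)nc1-c1ccccc1`: > 100000 nM (a limit)
- Compound 3 `O=Cc1cn(-c2ccc(O)cc2)nc1-c1ccccc1`: > 100000 nM (a limit)

Compound 3 gives > 100000 nM, which is a limit of the assay and not a number. Compound 2 gives > 100000 nM, which is also a limit. Taken together, the evidence so far is the limit of > 100000 nM in this assay, at which 2 of the 3 values shown sit. Compound 3 therefore offers a floor to start from, but no exact potency.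

Compound 4 `CCOC(=O)/C=C/c1cn(-c2ccc(O)cc2)nc1-c1ccccc1` has 2-(ethoxycarbonyl)ethenyl in place of the formyl of compound 3, on an aromatic carbon: 2-(ethoxycarbonyl)ethenyl in place of formyl on an aromatic carbon.

For the measured compounds named here, the only measured step between two compounds is a step that the two limits leave unreadable from compound 2 to compound 3, so it gives no size to carry over. Going by the values given here, the one real number comes from compound 1, which gives 14000 nM. Compound 1 carries the same 2-(ethoxycarbonyl)ethenyl group, though its core is not identical to that of compound 4. On that basis, compound 4 is expected to be a stronger inhibitor than compound 3 in this assay, though probably weaker than compound 1, and it may still fall at the limit. The expected change is an at least 3.3-fold lower number from compound 3 to compound 4 (0.52 log units; beyond the scatter). For compound 4 the estimated value is 30000 nM, with an expected range from 10000 nM to 100000 nM.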

Compound 4, half-maximal inhibitory concentration: 29000 nM
Compound 4: the middle estimate sits 1.0-fold (0.01 log units) above what was measured, and the stated range covers the measured number.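

For the compounds shown here, compound 4 is the first compound with an unsubstituted phenyl group on the shared core to give a real number instead of a limit in this assay, so the group on this aromatic carbon of the five-membered ring can bring measurable activity: 2-(ethoxycarbonyl)ethenyl in place of formyl gives an at least 3.4-fold lower number from compound 3 to compound 4 (0.53 log units; beyond the scatter). The ethyl group of the ester counts as well, with ethyl in place of hydrogen on an oxygen next to a carbonyl group giving an at least 3.4-fold lower number from compound 2 to compound 4 (0.53 log units; beyond the scatter), and both sizes are only minimum sizes because one end of each step is a limit: the limit of > 100000 nM in this assay, at which 2 of the 4 values shown sit. The comparison with compound 1 adds a second, separate change, as hydrogen in place of hydroxy on an aromatic carbon gives a 2.1-fold higher number from compound 1 to compound 4 (0.32 log units; beyond the scatter), so the hydroxy group of compound 1 goes with a modest gain on top of the ester.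

Going by these compounds, whether a methyl ester, a primary amide or a longer chain on the five-membered ring would lower the number further stays open, as does whether the double bond matters, which a saturated ethyl propanoate chain would test. On these data alone, it is also open whether a methoxy group or an amine could stand in for the hydroxy group of compound 1.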